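Trifluoromethyl for chloro, second instance on the series

The compounds below may be only part of what the source reports. "The series", "measured", "known", "first", "only" and "open" are said of these compounds alone.

Compound 1 `O=S(=O)(c1ccccc1)c1nc2ccccc2nc1Nc1ccc(Cl)cc1` is the reference. In a functional assay on KB cells (Homo sapiens) for cytotoxicity, read by MTT assay, with a stated time of 72 h (on this read-out lower numbers stand for stronger inhibition and higher numbers for weaker inhibition), compound 1 gives 41200 nM. Compound 2 `O=S(=O)(c1ccccc1)c1nc2ccccc2nc1Nc1ccc(C(F)(F)F)cc1` differs from it by trifluoromethyl in place of chloro on an aromatic carbon. In this assay compound 2 gives only a limit, > 50000 nM. The step of an at least 1.2-fold higher number from compound 1 to compound 2 (0.08 log units; that floor lies within the scatter) is thus known only as a floor, set by the limit of > 50000 nM in this assay, at which 1 of the 3 values shown sits.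

Compound 3 `COc1ccc(S(=O)(=O)c2nc3ccccc3nc2Nc2ccc(Cl)cc2)cc1` differs from compound 1 by methoxy in place of hydrogen on an aromatic carbon. In this assay compound 3 gives 49800 nM, which is a 1.2-fold higher number from compound 1 to compound 3 (0.08 log units; within the scatter).

Compound 4 `COc1ccc(S(=O)(=O)c2nc3ccccc3nc2Nc2ccc(C(F)(F)F)cc2)cc1` has not been measured. It differs from compound 3 by trifluoromethyl in place of chloro on an aromatic carbon, which is the same change as that from compound 1 to compound 2; the place is described in the same words in both cases. The step to compound 4 is expected to be a 1.3-fold higher number from compound 3 to compound 4 (0.12 log units; within the scatter), resting on the floor of an at least 1.2-fold higher number from compound 1 to compound 2 (0.08 log units; that floor lies within the scatter). It rests as well on the value of compound 3, 49800 nM. That value of compound 3 already lies close to the limit of > 50000 nM in this assay, at which 1 of the 3 values shown sits. Compound 4 is therefore estimated at 65000 nM, between 45000 nM and 150000 nM, and a reported limit rather than a number is quite likely.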

Compound 4, half-maximal inhibitory concentration: 890 nM
The estimate for compound 4 lay 73-fold (1.86 log units) above the measured number; the measured number lies below the stated range.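

In this assay, trifluoromethyl in place of chloro gives a 56-fold lower number from compound 3 to compound 4 (1.75 log units; beyond the scatter), and this does not match the step seen for the same change on the core of compound 1: the same change on two cores in this assay, an at least 1.2-fold higher number (0.08 log units; that floor lies within the scatter) from compound 1 to compound 2 and a 56-fold lower number (1.75 log units; beyond the scatter) from compound 3 to compound 4, at least 67-fold (1.83 log units) apart, beyond the scatter of two such steps. Methoxy in place of hydrogen also differs with the group it is paired with, giving an at least 56-fold lower number from compound 2 to compound 4 (1.74 log units; beyond the scatter), which does not match the step seen with chloro present: the same change on two cores in this assay, a 1.2-fold higher number (0.08 log units; within the scatter) from compound 1 to compound 3 and an at least 56-fold lower number (1.74 log units; beyond the scatter) from compound 2 to compound 4, at least 67-fold (1.83 log units) apart, beyond the scatter of two such steps. Compound 2 gives only a limit, > 50000 nM, so both gaps are floors; the finding rests on compound 4 alone, showing that a step read on one core cannot be assumed on the other, but not why, nor whether this holds on any further core.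

The compounds shown leave open whether an ethoxy or a dimethylamino group in place of methoxy would keep the value of compound 4. They also leave open whether a nitrile in place of trifluoromethyl on the core of compound 4 would give a similar number.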